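The compounds below may be only part of what the source reports. "The series", "measured", "known", "first", "only" and "open" are said of these compounds alone.

Measured so far:
Compound 1, `CCCCc1oc2ccc(/N=C/c3ccc(C#N)cc3)cc2c1C(=O)c1ccc(OC)cc1`, gives 27.2 ug/mL.
Compound 2, `CCCCc1oc2ccc(/N=C/c3ccc(OC)cc3OC)cc2c1C(=O)c1ccc(OC)cc1`, gives 20.5 ug/mL.
Compound 3, `CCCCc1oc2ccc(/N=C/c3ccc(Cl)cc3Cl)cc2c1C(=O)c1ccc(OC)cc1`, gives 2.44 ug/mL.

These three numbers come from a functional assay, with a stated time of 30 min; on this read-out higher numbers stand for weaker inhibition and lower numbers for stronger inhibition. Compound 1 has the highest number of the three; compound 2 sits within the scatter of it, as a 1.3-fold lower number from compound 1 to compound 2 (0.12 log units; within the scatter), while compound 3 lies far beyond it, as an 11-fold lower number from compound 1 to compound 3 (1.05 log units; beyond the scatter).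

Compound 4, `CCCCc1oc2ccc(/N=C/c3ccc(O)cc3O)cc2c1C(=O)c1ccc(OC)cc1`, is not yet measured. It differs from compound 1 in one place: 2,4-dihydroxyphenyl in place of 4-cyanophenyl on a carbon with a double bond to nitrogen.

Two measured steps leave the same 4-cyanophenyl group: the step to compound 2 stayed within the scatter, the step to compound 3 was large. The entering 2,4-dihydroxyphenyl shares its substitution pattern with both. A lower number is therefore expected, though a smaller step than an 11-fold lower number from compound 1 to compound 3 (1.05 log units; beyond the scatter), with the scatter-sized change of a 1.3-fold lower number from compound 1 to compound 2 (0.12 log units; within the scatter) as the cautious end.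

Compound 4 is estimated at 12 ug/mL, with a range from 4 ug/mL to 35 ug/mL. This means an expected step of a 2.3-fold lower number from compound 1 to compound 4 (0.36 log units; beyond the scatter).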

Compound 4, half-maximal inhibitory concentration: 7.55 ug/mL
Estimate against measurement, compound 4: 1.6-fold (0.20 log units) above, and the stated range covers the measured number.
By their numbers in this assay, from the lowest: compound 3; then compound 4; then compounds 2 and 1 (each within the scatter of the next).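

In this assay, 2,4-dihydroxyphenyl on this carbon gives stronger inhibition than 4-cyanophenyl (a 3.6-fold lower number from compound 1 to compound 4 (0.56 log units; beyond the scatter)) and than 2,4-dimethoxyphenyl (a 2.7-fold lower number from compound 2 to compound 4 (0.43 log units; beyond the scatter)). It remains weaker than 2,4-dichlorophenyl (a 3.1-fold higher number from compound 3 to compound 4 (0.49 log units; beyond the scatter)), so with the substitution pattern held the same, the choice of group still separates compounds 2, 3 and 4 beyond the scatter. Nothing available explains these differences.

Within the data shown here, whether a ring carrying only one hydroxyl group would land nearer compound 3 or compound 2 remains open. So does the effect of amino groups in place of the hydroxyl groups.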